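Methoxyphenyl Thioureas Against Glioblastoma Cells: A Positional Swap

A few compounds are considered here, and "the series" means these few. Any claim that something is new, unique, unknown or untested is made for them only; others in the source may bear on it.

Compound 1, `COc1cccc(NC(=S)NC2CC(C)(C)Oc3ccc(Br)cc32)c1`: 66000 nM
Compound 2, `O=[N+]([O-])c1cccc(NC(=S)NCc2cccc(Cl)c2)c1`: 32000 nM
Compound 3, `CC1(C)CC(NC(=O)Nc2cccc(Cl)c2)c2cc(Cl)ccc2O1`: 21000 nM

All three were tested in a functional assay on U-373MG ATCC cells (Homo sapiens) for inhibition, read by MTT assay, with a stated time of 72 h; on this read-out higher numbers stand for weaker inhibition and lower numbers for stronger inhibition. Compound 1 stands at the highest number of the three; compound 2 lies below it and compound 3 lower still, both gaps beyond the usual scatter. The untested analogue is compound 4, `COc1ccc(NC(=S)NC2CC(C)(C)Oc3ccc(Br)cc32)cc1`, which differs from compound 1 only in the arrangement of the same atoms: 4-methoxyphenyl in place of 3-methoxyphenyl on an amide-type nitrogen. Going by the values given here, no pair of measured compounds shows what such a swap does, so the expected step of a 1.1-fold lower number from compound 1 to compound 4 (0.04 log units; within the scatter) is one within the scatter, with no direction favoured. For compound 4 the estimate in this assay is 60000 nM, in a range from 25000 nM to 150000 nM.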

Compound 4, half-maximal inhibitory concentration: 40000 nM
For compound 4 the middle estimate is 1.5-fold (0.18 log units) above the measured one; low and high end bracket the measured number.
By their numbers in this assay, from the lowest: compounds 3, 2, 4 and 1 (each within the scatter of the next, the first and the last beyond it).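

Going by these compounds alone, the swap offers the first direct reading at this position: in this assay, 4-methoxyphenyl in place of 3-methoxyphenyl on the amide-type nitrogen gives a 1.7-fold lower number from compound 1 to compound 4 (0.22 log units; within the scatter). This rearrangement of the same atoms therefore does not separate the two compounds on this read-out. No supporting evidence bears on this result.

The compounds shown leave open whether a different group on the phenyl ring in place of the methoxy, such as an amine or a carboxylic acid, would produce a step beyond the scatter.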